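The source may hold more compounds than are shown below. What is called first, only, known or untested is meant among the compounds shown, and "the series" means these compounds.

Compound 3 `CN(C)c1ccc2c(=O)c(C(=O)Nc3cc(F)cc(F)c3)cn(-c3ccc(Cl)c(OCCCCCCC[n+]4ccccc4)c3)c2n1` is recorded in an assay on LX2 cells for inhibition of COL1A1 promoter (Homo sapiens), read by a luciferase reporter, with a stated time of 24 h, tested at 20 uM (on this read-out higher numbers stand for a stronger effect at the one concentration tested and lower numbers for a weaker effect), as "not active" (no number reported), with no number behind it, so its standing rests on that word alone. Compound 4 `CN1CC[N+](C)(CCCCCCCOc2cc(-n3cc(C(=O)Nc4cc(F)cc(F)c4)c(=O)c4ccc(N(C)C)nc43)ccc2Cl)CC1` differs from it by a group of 8 heavy atoms (6 carbon, 2 nitrogen; one six-membered non-aromatic ring with 2 hetero atoms) in place of a group of 6 heavy atoms (5 carbon, 1 nitrogen; one six-membered aromatic ring with 1 hetero atom), on a saturated chain carbon, seven bonds along the chain from an oxygen on an aromatic ring. Going by the values given here, one measured step bears on this change, in the opposite direction. Compound 1 `Cc1ccc(-n2cc(C(=O)Nc3cc(F)cc(F)c3)c(=O)c3ccc(N(C)C)nc32)cc1OCCCCCCC[N+]12CCN(CC1)CC2` gives 5.07% in this assay, and compound 2 `Cc1ccc(-n2cc(C(=O)Nc3cc(F)cc(F)c3)c(=O)c3ccc(N(C)C)nc32)cc1OCCCCCCC[n+]1ccccc1` gives 39.7%. That step, a number 34.6 percentage points higher from compound 1 to compound 2 (beyond the scatter), placed an aromatic six-membered group of 6 heavy atoms in place of a non-aromatic group of 8 heavy atoms on a saturated chain carbon, seven bonds along the chain from an oxygen on an aromatic ring. Undoing that kind of change on an inactive parent gives no ground to expect a gain beyond the scatter. Compound 4 is therefore expected near 3% in this assay, estimated between -10% and 16%.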

Compound 4, a percentage reported as inhibition, at one concentration (the size of the read-out at that concentration, not a potency): 27.5%
Compound 4: the middle estimate sits 24.5 percentage points below what was measured, outside the stated range (above it).
By their numbers in this assay, from the lowest: compound 1; then compound 4; then compound 2.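

Going by these compounds alone, compound 3 carries no number in this assay, so no step to compound 4 can be read. The compounds shown leave open how large the effect of this group exchange is on the shared core, and no measurement here explains the result.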